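The source may report more compounds than this note shows. Statements on the series, on what has been measured and on what is new or still open speak of the compounds shown alone.

Measured compounds:
- compound 1, `CCOc1ccc2nc(NC(=O)COc3ccc4cc(/C=C5/SC(=O)NC5=O)ccc4c3)sc2c1`: 3600 nM
- compound 2, `O=C(COc1ccc2cc(/C=C3/SC(=O)NC3=O)ccc2c1)Nc1ccc([N+](=O)[O-])cc1`: 1700 nM
- compound 3, `O=C(CN1C(=O)S/C(=C/c2ccccn2)C1=O)Nc1nc2ccccc2s1`: 9300 nM

All three were tested in an assay on isolated protein for inhibition of histone deacetylase 4 (Homo sapiens), with a stated time of 1 h; a higher number here means a weaker inhibitor, a lower number a stronger inhibitor. Among them compound 2 carries the lowest number, and its separation from both neighbours is beyond the usual scatter: compound 1 sits at a higher number, and compound 3 sits higher still. On these three values compound 2 is therefore the strongest inhibitor of the set in this assay.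

The account now turns to compound 4, `O=C(COc1ccc2cc(/C=C3/SC(=O)NC3=O)ccc2c1)Nc1ccc(Br)c(Br)c1`, which has not yet been measured. It shares everything with compound 2 except one group on the amide-type nitrogen: 3,4-dibromophenyl in place of 4-nitrophenyl on an amide-type nitrogen. The group that leaves carries two hydrogen-bond acceptors and a double bond outside aromatic rings; the group that enters has none of either and carries two bromine atoms instead.

Among the compounds with values here, no measured pair in the set makes a change of this kind, so nothing in the data tells how large such a step is or in which direction it runs. With only the value of compound 2 as an anchor, the step from compound 2 to compound 4 is expected to be small, a 1.1-fold lower number from compound 2 to compound 4 (0.03 log units; within the scatter), and not clearly beyond the scatter in either direction. Compound 4 is accordingly estimated at 1600 nM, within a range from 500 nM to 5000 nM.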

Compound 4, half-maximal inhibitory concentration: 4900 nM
Compound 4: the middle estimate sits 3.1-fold (0.49 log units) below what was measured, and the stated range covers the measured number.
By their numbers in this assay, from the lowest: compound 2; then compounds 1, 4 and 3 (each within the scatter of the next, the first and the last beyond it).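

In this assay, within the data shown here, the pair gives the first reading of the group on the amide-type nitrogen: putting 3,4-dibromophenyl in place of 4-nitrophenyl brings a 2.9-fold higher number from compound 2 to compound 4 (0.46 log units; beyond the scatter) and so moves toward weaker inhibition, a modest step but one beyond the scatter. The earlier compounds shown here included no pair differing in one place, so they could not show that this group alone, with the rest of the structure held fixed, shifts the number, or that a group with two hydrogen-bond acceptors can give way to one with none and two bromine atoms at only this modest cost. No measurement here explains the direction of the step, and what in either group is responsible stays unaccounted for.

The compounds shown leave open whether the step comes from losing the nitro group, from gaining the two bromine atoms, or from both, which an unsubstituted phenyl or a phenyl carrying a single bromine would help to separate. They also leave open how a phenyl bearing an amine or a carboxylic acid would behave on this nitrogen, and whether the same exchange would run the same way on a different core.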